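A few compounds are considered here, and "the series" means these few. Any claim that something is new, unique, unknown or untested is made for them only; others in the source may bear on it.

Compound 1 `CC(C)c1cccc(C(C)C)c1NS(=O)(=O)CC(=O)Oc1c(C(C)C)cccc1C(C)C`: > 1000 nM
Compound 2 `CC(C)c1cc(C(C)C)c(NS(=O)(=O)CC(=O)Oc2c(C(C)C)cccc2C(C)C)c(C(C)C)c1`: > 1000 nM
Compound 3 `CCCCCCSC(=O)CS(=O)(=O)Nc1c(C(C)C)cccc1C(C)C`: 1000 nM

In an assay on microsomes from intestine for inhibition of acyl-CoA:cholesterol acyltransferase (Oryctolagus cuniculus) (a higher number here means a weaker inhibitor, a lower number a stronger inhibitor), compound 1 gives > 1000 nM, which is a limit of the assay and not a number. Compound 2 gives > 1000 nM, likewise a limit. The step that the two limits leave unreadable from compound 1 to compound 2 cannot be read because of the limit of > 1000 nM in this assay, at which 2 of the 3 values shown sit. Going by the values given here, compound 3 gives 1000 nM, the only number in this set. The values of compound 1 and compound 2 are limits of the assay, so compound 3 cannot be ranked against them.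

Compound 4 `CCCCCCCCCCCCCCCCCCSC(=O)CS(=O)(=O)Nc1c(C(C)C)cccc1C(C)C` differs from compound 3 by dodecyl in place of hydrogen on a saturated chain carbon, six bonds along the chain from a sulfur. Among the compounds with values here, no measured step bears on this change: the single step in the set concerns an aromatic isopropyl and is unreadable. The expectation therefore rests on compound 3 alone. A step of a 3.3-fold lower number from compound 3 to compound 4 (0.52 log units; beyond the scatter) is expected, tentatively toward stronger inhibition, with wide uncertainty. Compound 4 is estimated at 300 nM, within 50 nM to 2000 nM.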

Compound 4, half-maximal inhibitory concentration: > 5000 nM
Compound 4 was reported as a limit; the forecaster's own chance of this, stated with the estimate: 25%; middle value at least 16-fold (1.22 log units) from the limit.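

In this assay, dodecyl in place of hydrogen on a saturated chain carbon, six bonds along the chain from a sulfur, gives an at least 5.0-fold higher number from compound 3 to compound 4 (0.69 log units; beyond the scatter). Going by these compounds alone, this is the first readable step, and it runs toward weaker inhibition; the earlier step, on an aromatic isopropyl, cannot be read. As far as these compounds go, compound 4 gives > 5000 nM, a limit of the assay and not a number, so the full size of the loss stays unknown.

From the compounds shown here alone, whether a shorter chain, an amine or a carboxylic acid at this position would give a lower number than compound 3 stays open. One readable step supports no trend with chain length.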